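The source may hold more compounds than are shown below. What is called first, only, known or untested is meant among the compounds shown, and "the series" means these compounds.

Three compounds share one core and differ only in the side group on a saturated chain carbon bound to an amide-type nitrogen and a carbonyl carbon. In a functional assay on the whole organism (Tail, strain ICR) with Mus musculus as the target, in the tail flick test, with a stated time of 150 min, at a dose of 25 umol/kg by the oral route (a higher number here means a stronger effect of the compound at the dose given, a lower number a weaker effect), compound 1 `O=C(O)CNC(=O)CN(c1nc(Cl)nc2[nH]cnc12)C1CC1` gives 9.08%. Compound 2 `O=C(O)CC[C@H](NC(=O)CN(c1nc(Cl)nc2[nH]cnc12)C1CC1)C(=O)O` gives 29.5%, and compound 3 `CC(C)C[C@H](NC(=O)CN(c1nc(Cl)nc2[nH]cnc12)C1CC1)C(=O)O` gives 9.13%, a number within the scatter of compound 1 and clearly below compound 2. The move to compound 4 `NC(=O)CC[C@H](NC(=O)CN(c1nc(Cl)nc2[nH]cnc12)C1CC1)C(=O)O` is carbamoylmethyl in place of isopropyl on a saturated chain carbon, two bonds along the chain from an amide-type nitrogen and a carbonyl carbon. This largely reverses the step of a number 20.4 percentage points lower from compound 2 to compound 3 (beyond the scatter), which lay beyond the scatter, whereas the step of a number 0.1 percentage points higher from compound 1 to compound 3 (within the scatter) stayed within it. A carbamoylmethyl group is not a carboxymethyl group, so only part of that gain is expected: compound 4 is estimated at 20%, between 8% and 35%, an expected step of a number 10.9 percentage points higher from compound 3 to compound 4 (beyond the scatter).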

Compound 4, a percentage reported as activity, at one dose (the size of the read-out at that dose, not a potency): 11.4%
For compound 4 the middle estimate is 8.6 percentage points above the measured one; measured number inside the range.
By their numbers in this assay, from the lowest: compounds 1, 3 and 4 (each within the scatter of the next); then compound 2.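

Replacing hydroxy with amino on the side-chain carbonyl removes most of the effect seen in this assay (a number 18.1 percentage points lower from compound 2 to compound 4 (beyond the scatter)). The 2-carbamoylethyl group does not separate from isobutyl (a number 2.3 percentage points higher from compound 3 to compound 4 (within the scatter)) or from hydrogen (a number 2.3 percentage points higher from compound 1 to compound 4 (within the scatter)), so among these side groups only the 2-carboxyethyl of compound 2 stands apart. No evidence here explains this difference.

From the compounds shown here alone, it remains open whether a longer chain ending in a carboxylic acid would keep the effect of compound 2. Going by these compounds, an amine at the chain end also remains untested.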